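Kallikrein-7 series: fluoro for chloro on the benzyl ring

The source may report more compounds than this note shows. Statements on the series, on what has been measured and on what is new or still open speak of the compounds shown alone.

Compound 1, `Cc1cccc(C)c1CC1CN/C(=N\N(C)C)CN(CC(=O)Nc2cccc(-c3cnn(C)c3)c2)C1=O`: 5200 nM
Compound 2, `Cc1cccc(Cl)c1CC1CN/C(=N\N(C)C)CN(CC(=O)Nc2cccc(-c3cnn(C)c3)c2)C1=O`: 1500 nM
Compound 3, `CN(C)/N=C1/CN(CC(=O)Nc2cccc(-c3cnn(C)c3)c2)C(=O)C(Cc2c(F)cccc2F)CN1`: 6900 nM

In an assay on isolated protein for inhibition of kallikrein-7 (Homo sapiens), read by fluorescence, with stated times of 10 min and 30 min (on this read-out higher numbers stand for weaker inhibition and lower numbers for stronger inhibition), compound 2 gives the lowest number of the three; the steps of a 3.5-fold lower number from compound 1 to compound 2 (0.54 log units; beyond the scatter) and a 4.6-fold higher number from compound 2 to compound 3 (0.66 log units; beyond the scatter) both lie beyond the scatter, while a 1.3-fold higher number from compound 1 to compound 3 (0.12 log units; within the scatter) does not. Compound 4, `Cc1cccc(F)c1CC1CN/C(=N\N(C)C)CN(CC(=O)Nc2cccc(-c3cnn(C)c3)c2)C1=O`, carries one change from compound 2: fluoro in place of chloro on an aromatic carbon. Going by the values given here, two measured steps bear on this. The step of a 3.5-fold lower number from compound 1 to compound 2 (0.54 log units; beyond the scatter) shows that chloro at this position is better than methyl; the step of a 4.6-fold higher number from compound 2 to compound 3 (0.66 log units; beyond the scatter) shows that exchanging the chloro-methyl pair for two fluoro atoms costs a modest amount. Fluoro alone at the chloro position is therefore expected to sit between these outcomes, a modest rise in number: a 2.3-fold higher number from compound 2 to compound 4 (0.37 log units; beyond the scatter). For compound 4 in this assay the estimate is 3500 nM, with a range of 1500 nM to 8000 nM.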

Compound 4, half-maximal inhibitory concentration: 2300 nM
Beside the measured number, compound 4's estimate is 1.5-fold (0.18 log units) above it, within the range that was stated.
By their numbers in this assay, from the lowest: compounds 2 and 4 (each within the scatter of the next); then compounds 1 and 3 (each within the scatter of the next).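

In this assay fluoro and chloro at this position cannot be told apart, as a 1.5-fold higher number from compound 2 to compound 4 (0.19 log units; within the scatter) stays within the scatter. Fluoro still improves on methyl here, with a 2.3-fold lower number from compound 1 to compound 4 (0.35 log units; beyond the scatter) as the measured step, so this advantage over methyl is not unique to chloro. The other ring substituent also counts, since a 3.0-fold lower number from compound 3 to compound 4 (0.48 log units; beyond the scatter) accompanies methyl in place of fluoro on the 2,6-difluorophenyl ring. On these data alone, whether a methoxy group or an amine at this position would keep the advantage remains open. Nothing shown explains these steps.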